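Swapping piperidin-1-yl for acetamido on a shared core

The source may hold more compounds than are shown below. What is called first, only, known or untested is meant among the compounds shown, and "the series" means these compounds.

Compound 1 `CCNc1cc2nc(-c3ccccc3)nn(-c3ccccc3)c-2cc1=O`: 1620 nM
Compound 2 `O=c1cc2n(-c3ccccc3)nc(-c3ccccc3)nc-2cc1N1CCCCC1`: 1980 nM

For the measured compounds named here, both values come from a functional assay on MCF7 cells (Homo sapiens) for cytotoxicity, read by MTT assay, with a stated time of 72 h (on this read-out higher numbers stand for weaker inhibition and lower numbers for stronger inhibition), and are the only numbers available so far. Compound 2 at 1980 nM cannot be told apart from compound 1 at 1620 nM, since the two lie within the usual scatter of repeated measurements.

The next compound, compound 3 `CC(=O)Nc1cc2nc(-c3ccccc3)nn(-c3ccccc3)c-2cc1=O`, keeps the shared core and has acetamido in place of piperidin-1-yl on an aromatic carbon. The counted difference is acetamido in place of piperidin-1-yl on an aromatic carbon.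

Going by the values given here, only one measured step bears on this change. In that step, a 1.2-fold higher number from compound 1 to compound 2 (0.09 log units; within the scatter), piperidin-1-yl replaced ethylamino on an aromatic carbon. Swapping these two groups left the number within the scatter, which offers no reason to expect a large shift. Among the compounds with values here, it is only weak guidance, however, as no measured compound carries acetamido.

No step beyond the scatter is therefore expected in this assay, and the expected size is a 1.0-fold higher number from compound 2 to compound 3 (0.00 log units; within the scatter) in either direction at this stage.

Compound 3 is estimated at 2000 nM with an expected range of 700 nM to 6000 nM as a deliberately wide span.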

Compound 3, half-maximal inhibitory concentration: > 5000 nM
Compound 3 ended at the assay's limit; the forecaster's own chance of this, stated with the estimate: 8%; at least 2.5-fold (0.39 log units) between middle value and limit.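

In this assay compound 3 stands at a limit of the assay, not at a number: the limit of > 5000 nM in this assay, at which 1 of the 3 values shown sits.

Until now this aromatic carbon had shown no sign of telling its groups apart, as ethylamino and piperidin-1-yl gave values within the scatter of each other. Acetamido breaks that picture, with an at least 2.5-fold higher number from compound 2 to compound 3 (0.40 log units; beyond the scatter) against the ring-bearing group. The closest comparison is the swap of acetyl for ethyl on the nitrogen attached to the aromatic ring, which gives an at least 3.0-fold higher number from compound 1 to compound 3 (0.48 log units; beyond the scatter) and shows that the group on that nitrogen can matter even when the nitrogen itself stays in place.

For the compounds shown here, how much weaker compound 3 truly is remains open, as does the question of whether the carbonyl of acetamido is the feature that matters, since the three compounds offer only one group that carries it. A free primary amine, a longer acyl chain such as propionamido, or a methanesulfonamide on the same aromatic carbon would help to separate these possibilities.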